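The source may report more compounds than this note shows. Statements on the series, on what has been measured and on what is new or still open speak of the compounds shown alone.

Of the compounds shown here, two have so far been tested in an assay on isolated protein for inhibition of polyamine deacetylase HDAC10 (Homo sapiens); a higher number here means a weaker inhibitor, a lower number a stronger inhibitor. Compound 1 `COc1ccc(C(=O)c2ccc3c(ccn3S(=O)(=O)c3cccc(/C=C/C(=O)NO)c3)c2)cc1OC` gives 8240 nM, the lower of the two numbers, while compound 2 `COc1cccc(C(=O)c2ccc3c(ccn3Cc3ccc(C(=O)NO)cc3)c2)c1` gives 47900 nM in this assay, a weaker result that lies beyond the usual scatter. Compound 3 `Cc1ccc(C(=O)c2ccc3c(ccn3S(=O)(=O)c3cccc(/C=C/C(=O)NO)c3)c2)cc1` differs from compound 1 in one place: 4-methylphenyl in place of 3,4-dimethoxyphenyl on a carbonyl carbon. Among the compounds with values here, no pair of measured compounds isolates this change, so there is nothing to anchor its effect. The step of a 1.2-fold higher number from compound 1 to compound 3 (0.08 log units; within the scatter) is expected to stay within the scatter, in either direction. Compound 3 is therefore estimated at 10000 nM, in a range from 4000 nM to 25000 nM.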

Compound 3, half-maximal inhibitory concentration: 9100 nM
Beside the measured number, compound 3's estimate is 1.1-fold (0.04 log units) above it; measured number inside the range.
By their numbers in this assay, from the lowest: compounds 1 and 3 (each within the scatter of the next); then compound 2.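

In this assay, the first step read at this position, on a carbonyl carbon, is a 1.1-fold higher number from compound 1 to compound 3 (0.04 log units; within the scatter). Thus 4-methylphenyl, with 7 heavy atoms and 0 hydrogen-bond acceptors, can stand in place of 3,4-dimethoxyphenyl, with 10 heavy atoms and 2 hydrogen-bond acceptors, without a difference beyond the scatter. Nothing available explains this result. This rests on a single pair of compounds. From the compounds shown here alone, whether an amine or a carboxylic acid on the phenyl ring at this position would also stay within the scatter remains open.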